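The compounds below may be only part of what the source reports. "The series", "measured", "known", "first", "only" and "open" are said of these compounds alone.

In a functional assay on K562 cells (Homo sapiens) for antiproliferative activity, with a stated time of 72 h (a higher number here means a weaker inhibitor, a lower number a stronger inhibitor), compound 1 `CCCC#Cc1cc([C@@H]2O[C@H](CO)[C@@H](O)[C@H]2O)n2ncnc(N)c12` gives 1100 nM and compound 2 `CCCCC#Cc1cc([C@@H]2O[C@H](CO)[C@@H](O)[C@H]2O)n2ncnc(N)c12` gives 2400 nM, the higher of the two numbers, which makes compound 2 the weaker inhibitor. Compound 3 `Nc1ncnn2c([C@@H]3O[C@H](CO)[C@@H](O)[C@H]3O)cc(C#CC3CC3)c12` changes compound 2 as follows: cyclopropyl in place of butyl on a triple-bonded carbon. Among the measured compounds shown here, only one measured step bears on this: a 2.2-fold higher number from compound 1 to compound 2 (0.34 log units; beyond the scatter), a modest step that came with methyl in place of hydrogen on a saturated chain carbon. For the measured compounds named here, no cyclopropyl compound has been measured, so the expectation is loose, a modest move toward a lower number. The expected change is a 2.4-fold lower number from compound 2 to compound 3 (0.38 log units; beyond the scatter). Compound 3 is estimated at 1000 nM, with an expected range of 350 nM to 2800 nM.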

Compound 3, half-maximal inhibitory concentration: 40 nM
Compound 3: middle estimate off by 25-fold (1.40 log units), on the high side; the measured number lies below the stated range.
By their numbers in this assay, from the lowest: compound 3; then compound 1; then compound 2.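

On the triple-bonded carbon, the group's shape matters far more than the earlier chain-lengthening step suggested. In this assay the cyclopropyl ring gives a change much larger than the earlier one (a 2.2-fold higher number from compound 1 to compound 2 (0.34 log units; beyond the scatter)) when set against butyl (a 60-fold lower number from compound 2 to compound 3 (1.78 log units; beyond the scatter)) and against propyl (a 28-fold lower number from compound 1 to compound 3 (1.44 log units; beyond the scatter)). No available evidence explains this gain.

From the compounds shown here alone, it remains open whether the gain is specific to the three-membered ring. A cyclobutyl or phenyl group on the same triple-bonded carbon would show whether other rings do as well.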